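Solubility notes: alkoxy for alkylamino on the shared core

The compounds below may be only part of what the source reports. "The series", "measured", "known", "first", "only" and "open" are said of these compounds alone.

compound 1, `CS(=O)(=O)c1ccc(-n2nc(C(F)(F)F)c(C#N)c2-c2ccccc2)nc1`: 100 ug/mL
compound 2, `CC(C)(C)CNc1c(C#N)c(C(F)(F)F)nn1-c1ccc(S(C)(=O)=O)cn1`: < 25 ug/mL

In a physicochemical assay for solubility (on this read-out higher numbers stand for higher solubility and lower numbers for lower solubility), compound 1 gives 100 ug/mL. For compound 2 this assay reports only a limit, < 25 ug/mL. Among the compounds with values here, the single measured step, an at least 4.0-fold lower number from compound 1 to compound 2 (0.60 log units; beyond the scatter), places compound 2 at the low end of the two values shown, and the limit of < 25 ug/mL in this assay, at which 1 of the 2 values shown sits, means its true number is not fixed, only bounded.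

Compound 3, `CC(C)COc1c(C#N)c(C(F)(F)F)nn1-c1ccc(S(C)(=O)=O)cn1`, is not yet measured in this assay. It differs from compound 2 as follows: isobutoxy in place of neopentylamino on an aromatic carbon. Within the data shown here, no measured step pairs these two groups, so the size of this change cannot be read from the data on hand; the only measured step says merely that compound 2 already sits at the limit. The expectation for compound 3 is therefore a number near that limit, with a step that the limit leaves unreadable from compound 2 to compound 3 as the implied step. Compound 3 is estimated at 15 ug/mL, between 4 ug/mL and 50 ug/mL, with a fair chance that this assay again reports only a limit.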

Compound 3, solubility: < 25 ug/mL
Compound 3 gave a limit, no number; the forecaster's own chance of this, stated with the estimate: 65%; the middle value does not contradict the limit.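

In this assay, isobutoxy in place of phenyl on this aromatic carbon gives an at least 4.0-fold lower number from compound 1 to compound 3 (0.60 log units; beyond the scatter), so two different non-aromatic chains at this position now show a lower number than the phenyl of compound 1. Isobutoxy has 0 hydrogen-bond donors where neopentylamino has 1, and compound 3 still returns only a limit, < 25 ug/mL. The step between compound 2 and compound 3 cannot be read, because both compounds sit at the same limit of the assay: the limit of < 25 ug/mL in this assay, at which 2 of the 3 values shown sit.

From the compounds shown here alone, how far the true values of compound 2 and compound 3 lie under that limit remains open, as does whether the exchange of neopentylamino for isobutoxy changes solubility at all. Also open, going by these compounds, is whether a shorter chain such as methoxy, or an isobutoxy-sized chain ending in an amine or a carboxylic acid, would bring this position back to a measurable number that could be set against compound 1.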